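The source may report more compounds than this note shows. Statements on the series, on what has been measured and on what is new or still open speak of the compounds shown alone.

Within the data shown here, compound 2, `COc1ccc(-c2cc(C(=O)/C=C/c3ccc(C)cc3)nc3cc(-c4ccccc4)nn23)cc1OC`, gives 19500 nM in a functional assay on DU-145 cells (Homo sapiens) for antiproliferative activity, read by MTT assay, with a stated time of 24 h (a lower number here means a stronger inhibitor, a higher number a weaker inhibitor), the highest of the two numbers known so far. Among the measured compounds shown here, its nearest neighbour, compound 1, `COc1ccc(-c2cc(/C=C/C(=O)c3cc(OC)c(OC)c(OC)c3)nc3cc(-c4ccccc4)nn23)cc1OC`, gives 8300 nM in this assay, a lower number than compound 2 by a margin beyond the scatter; no single-point step links these two, so their values stand side by side without a counted difference. Compound 3, `COc1ccc(C(=O)/C=C/c2cc(-c3ccc(OC)c(OC)c3)n3nc(-c4ccccc4)cc3n2)cc1`, is not yet measured. It differs from compound 2 in one place: 2-((4-methoxyphenyl)carbonyl)ethenyl in place of (2-(4-methylphenyl)ethenyl)carbonyl on an aromatic carbon. With this change the carbonyl moves off the shared core onto the outer ring, an arrangement that compound 1 also shows. Since compound 1 gives 8300 nM and compound 2 gives 19500 nM, the step from compound 2 to compound 3 is expected to be a modest move toward a lower number, a 1.8-fold lower number from compound 2 to compound 3 (0.25 log units; within the scatter). Compound 3 is therefore estimated at 11000 nM, within 4000 nM to 28000 nM.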

Compound 3, half-maximal inhibitory concentration: 14600 nM
Beside the measured number, compound 3's estimate is 1.3-fold (0.12 log units) below it; measured number inside the range.
By their numbers in this assay, from the lowest: compounds 1, 3 and 2 (each within the scatter of the next, the first and the last beyond it).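

At the aromatic carbon next to the ring nitrogen, 2-((4-methoxyphenyl)carbonyl)ethenyl in place of (2-(4-methylphenyl)ethenyl)carbonyl gives a 1.3-fold lower number from compound 2 to compound 3 (0.13 log units; within the scatter) in this assay, so exchanging these two groups at this position does not separate the compounds beyond the scatter. Among these compounds, the new compound also gives a first comparison on the outer ring: 4-methoxyphenyl in place of 3,4,5-trimethoxyphenyl on a carbonyl carbon gives a 1.8-fold higher number from compound 1 to compound 3 (0.25 log units; within the scatter), and this change likewise stays inside the scatter. Nothing available here accounts for the size of either step. The compounds shown leave open whether an amine or a carboxylic acid on the outer ring would shift the number beyond the scatter. They also leave open what a longer chain in place of the ethenyl unit would do at this position.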